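Fluoro for amino on a bridged bicyclic: stability outlook

The compounds below may be only part of what the source reports. "The series", "measured", "known", "first", "only" and "open" are said of these compounds alone.

Four compounds share one core. Compound 1 `COC1(c2nnc3c(Oc4cccc(Cl)c4C)cccn23)CCCCCC1` and compound 2 `Cc1c(Cl)cccc1Oc1cccn2c(C3CCC(C)(O)CC3)nnc12` differ in one place, while compound 3 `Cc1c(Cl)cccc1Oc1cccn2c(C34CCC(N)(CC3)CC4)nnc12` and compound 4 `Cc1c(Cl)cccc1Oc1cccn2c(C34CCC(F)(CC3)CC4)nnc12` carry bridged bicyclic groups. In an ADME assay on microsomes from liver (Homo sapiens) for metabolic stability, with a stated time of 10 min (on this read-out lower numbers stand for a less stable compound and higher numbers for a more stable compound), compound 1 gives only a limit of < 1%. In this assay compound 2 gives 99%. The step of a number at least 98 percentage points higher from compound 1 to compound 2 (beyond the scatter) is large. For compound 3 the outcome in this assay is "not determined" (no result reported), so it stands nowhere on the numbers shown. Compound 4 differs from compound 3 by fluoro in place of amino on a saturated ring carbon. Within the data shown here, no measured step concerns either compound, and the change from compound 1 to compound 2 lies elsewhere, so it gives no direct guide to the size or direction of the step in this assay. Compound 4 is estimated to give about 60%, expected between 20% and 95%.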

Compound 4, percent of the compound remaining: 76%
The estimate for compound 4 lay 16 percentage points below the measured number; the measured number falls inside the stated range.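

Among these compounds, compound 4 gives the first reading for a bridged bicyclic group in this assay, and it shows a fluoro-bearing bridged group holding most of the stability seen at this position: the outcome is a number 23 percentage points lower from compound 2 to compound 4 (beyond the scatter), and also a number at least 75 percentage points higher from compound 1 to compound 4 (beyond the scatter). The value for compound 1 is a limit and not a number: the limit of < 1% in this assay, at which 1 of the 4 values shown sits.

Going by these compounds, the step from compound 3 to compound 4 cannot be read, so the effect of fluoro in place of amino stays open. On these data alone, how a nitrile or a carboxylic acid on that saturated ring carbon would fare in this assay also stays open.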